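Predicting Compound 4: A Second Hydroxy on the Core

The source may hold more compounds than are shown below. What is called first, only, known or untested is meant among the compounds shown, and "the series" means these compounds.

Compound 1 `C=C1CC[C@@H]2[C@](C)(CO)[C@H](O)CC[C@@]2(C)[C@@H]1CCC1=CCOC1=O` gives 21000 nM in a functional assay on RAW264.7 cells (Mus musculus) for inhibition, read by Griess assay, with a stated time of 24 h; on this read-out higher numbers stand for weaker inhibition and lower numbers for stronger inhibition.
Compound 2 `C=C1[C@H](O)C[C@H]2[C@@](C)(CCC(=O)[C@@]2(C)CO)[C@@H]1CCC1=CCOC1=O` gives 58300 nM in this assay.
Compound 3 `C=C1CC[C@H]2[C@@](C)(CCC(=O)[C@@]2(C)CO)[C@@H]1CCC1=CCOC1=O` gives 10100 nM in this assay.

Among these three, compound 3 shows the lowest number and compound 2 the highest, with compound 1 standing in the middle; each of these gaps is beyond the usual scatter. Compound 2 and compound 3 share a core and differ in one place only, (hydroxy in place of hydrogen on a saturated ring carbon), and that change made a 5.8-fold higher number from compound 3 to compound 2 (0.76 log units; beyond the scatter). Compound 1 has a different core from compound 3; how the two cores differ is not broken down here, so only their two values can be compared.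

Compound 4 `C=C1CC[C@@H]2[C@](C)(CO)[C@H](O)C[C@@H](O)[C@@]2(C)[C@@H]1CCC1=CCOC1=O` has not yet been measured. It differs from compound 1 by hydroxy in place of hydrogen on a saturated ring carbon. Within the data shown here, this is the same kind of change as the one from compound 3 to compound 2, not the same one: in compound 4 the new hydroxy group sits next to the ring atom that bears a fused ring and next to the ring atom that bears a methyl group, two ring bonds from a ring atom that already bears a hydroxy group, whereas in compound 2 it sits two ring bonds from the ring atom that bears a group of 8 heavy atoms.

Because the earlier change gave a 5.8-fold higher number from compound 3 to compound 2 (0.76 log units; beyond the scatter), the expected step for compound 4 is a 3.8-fold higher number from compound 1 to compound 4 (0.58 log units; beyond the scatter), somewhat smaller to allow for the different surroundings. Compound 4 is therefore estimated at 80000 nM, most likely between 30000 nM and 220000 nM.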

Compound 4, half-maximal inhibitory concentration: > 100000 nM
Compound 4 was reported as a limit (the forecaster's own chance of this, stated with the estimate: 25%); at least 1.2-fold (0.09 log units) between middle value and limit.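

In this assay, compound 4 is reported only as a limit of the assay, > 100000 nM, and not as an exact number. Even so, putting hydroxy in place of hydrogen on a saturated ring carbon gave an at least 4.7-fold higher number from compound 1 to compound 4 (0.67 log units; beyond the scatter), so on both cores the change moved the number in the same direction, towards weaker inhibition: the same change on two cores in this assay, a 5.8-fold higher number (0.76 log units; beyond the scatter) from compound 3 to compound 2 and an at least 4.7-fold higher number (0.67 log units; beyond the scatter) from compound 1 to compound 4; the limit leaves it open whether they differ. Going by these compounds, this does not show that the step has the same size on both cores, nor does it make a general rule, as it rests on just two pairs of compounds with the new hydroxy in different surroundings, and the exact value for compound 4 remains unknown because it sits at the limit: the limit of > 100000 nM in this assay, at which 1 of the 4 values shown sits.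

On these data alone, the new group in both pairs is hydroxy, so it remains open whether a methoxy group, a fluorine atom or an amine on the same ring carbon would move the number in the same way. As far as these compounds go, it also remains open whether a hydroxy on another saturated ring carbon of the core of compound 1 would give a step of similar direction and size.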